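This account rests on a few compounds, and the source may have more. Where it says the series, first, only, none or still open, it means among the compounds named here.

Compound 1 `Cc1ccc2nc(N)nc(O)c2c1` gives 4.44 in an assay for inhibition of Dihydrofolate reductase (Homo sapiens); on this read-out higher numbers stand for higher potency (the scale is a negative logarithm) and lower numbers for lower potency. Among the measured compounds shown here, compound 3 `Cc1ccc2nc(N)nc(N)c2c1`, which carries amino in place of hydroxy on an aromatic carbon, gives 5.66 in this assay; the step of a number 1.22 log units higher from compound 1 to compound 3 (beyond the scatter) is the only one measured for this change. Compound 2 `Nc1nc(O)c2c(Sc3ccc4ccccc4c3)cccc2n1` gives 6.15 in this assay, the highest of the three; the difference between its core and the core of compound 1 is not broken down here. Compound 4 `Nc1nc(N)c2c(Sc3ccc4ccccc4c3)cccc2n1` has not yet been measured; it carries amino in place of hydroxy on an aromatic carbon, the same change as from compound 1 to compound 3, at the same place. Because of a number 1.22 log units higher from compound 1 to compound 3 (beyond the scatter), a step of similar size, a number 1.22 log units higher from compound 2 to compound 4 (beyond the scatter), is expected from compound 2 to compound 4 in this assay, resting on a single pair. Compound 4 is therefore estimated at 7.37 in this assay, between 6.7 and 7.9.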

Compound 4, logarithm of the reciprocal of the active concentration, log(1/C): 6.92
For compound 4 the middle estimate is 0.45 log units above the measured one, and the stated range covers the measured number.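

Amino in place of hydroxy gives a number 0.77 log units higher from compound 2 to compound 4 (beyond the scatter) in this assay and so keeps the direction seen on the core of compound 1. The size of the step does not carry over unchanged: the same change on two cores in this assay, a number 1.22 log units higher (beyond the scatter) from compound 1 to compound 3 and a number 0.77 log units higher (beyond the scatter) from compound 2 to compound 4, 0.45 log units apart, beyond the scatter of two such steps. Two pairs give no reason for this gap and no rule for the size of the step on a third core.

The compounds shown leave open how other groups in the same place compare with amino and hydroxy, for example methoxy or methylamino. Also open, as far as these compounds go, is whether the step changes with the other substituent on the core, which would need further pairs carrying, for example, a chlorine or a longer chain instead.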